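Swapping the aryl group of a thiosemicarbazone: hydroxy to nitro

The source may report more compounds than this note shows. Statements on the series, on what has been measured and on what is new or still open speak of the compounds shown alone.

Compound 1 `CC1=CC[C@@H]([C@@](C)(O)CCCC(C)(C)NC(=S)N/N=C\c2ccc(C)cc2)CC1`: in a functional assay on NCI-H460 cells (Homo sapiens) for cytotoxicity, read by sulforhodamine B assay (on this read-out higher numbers stand for weaker inhibition of growth and lower numbers for stronger inhibition of growth), compound 1 gives > 100000 nM, which is a limit of the assay rather than a number.
Compound 2 `COc1ccc(/C=N\NC(=S)NC(C)(C)CCC[C@](C)(O)[C@@H]2CC=C(C)CC2)cc1`: in this assay compound 2 gives > 100000 nM, again a limit rather than a number.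
Compound 3 `CC1=CC[C@@H]([C@@](C)(O)CCCC(C)(C)NC(=S)N/N=C\c2ccc(O)cc2)CC1`: in this assay compound 3 gives 20700 nM.

For the measured compounds named here, compound 3 therefore holds the only measured number among the three; the other two sit at the limit of > 100000 nM in this assay, at which 2 of the 3 values shown sit. The step of an at least 4.8-fold lower number from compound 1 to compound 3 (0.68 log units; beyond the scatter) and the step of an at least 4.8-fold lower number from compound 2 to compound 3 (0.68 log units; beyond the scatter) both show that bringing in the free hydroxy on the aromatic ring moved the value out of the limit region and into measurable territory.

Compound 4 `CC1=CC[C@@H]([C@@](C)(O)CCCC(C)(C)NC(=S)N/N=C\c2ccccc2[N+](=O)[O-])CC1` is the unmeasured analogue. Its difference from compound 3 is 2-nitrophenyl in place of 4-hydroxyphenyl on a carbon with a double bond to nitrogen. The hydroxy-bearing ring thus departs and a nitro-bearing ring takes its place. Going by the values given here, two measured steps bear on this change: an at least 4.8-fold lower number from compound 1 to compound 3 (0.68 log units; beyond the scatter) and an at least 4.8-fold lower number from compound 2 to compound 3 (0.68 log units; beyond the scatter), each at least modest and each running toward a lower number only when the hydroxy arrived. Without that hydroxy, compound 4 is expected to drift back toward weaker inhibition, so the expected step of a 3.4-fold higher number from compound 3 to compound 4 (0.53 log units; beyond the scatter) points toward a higher number. The estimated value for compound 4 in this assay is 70000 nM, within a range from 15000 nM to 300000 nM.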

Compound 4, concentration for total growth inhibition: > 100000 nM
Compound 4: a limit, no number; the forecaster's own chance of this, stated with the estimate: 55%; middle value at least 1.4-fold (0.15 log units) from the limit.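

Putting 2-nitrophenyl in place of 4-hydroxyphenyl on the carbon with a double bond to nitrogen gives an at least 4.8-fold higher number from compound 3 to compound 4 (0.68 log units; beyond the scatter), so at this position in this assay, the measurable growth inhibition seen with compound 3 does not carry over to a ring bearing a nitro group. The result for compound 4 is a limit of the assay, not a number, and it places this nitro-bearing ring with the methyl-bearing and methoxy-bearing rings of compound 1 and compound 2, leaving compound 3 as the only compound of the four with a measured number: the limit of > 100000 nM in this assay, at which 3 of the 4 values shown sit. The steps from compound 1 and from compound 2 to compound 4 cannot be read, as limits stand at both ends, so no order among these three can be given.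

The name 2-nitrophenyl differs from 4-hydroxyphenyl in both the group and the number, and the compounds shown cannot separate what each of these contributes. Going by these compounds, it also stays open whether an amine or a carboxylic acid on the ring would give a measurable number, as the hydroxy group of compound 3 does.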